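Removing the bromo from the amino-linked urea: lipophilicity notes

This account rests on a few compounds, and the source may have more. Where it says the series, first, only, none or still open, it means among the compounds named here.

Compound 1 `O=C(Nc1ccc(NC2=NS(=O)(=O)c3ccccc32)cc1)Nc1cccc(Br)c1` carries the shared core joined through an amino link to a diaryl urea, and in a physicochemical assay for lipophilicity (on this read-out higher numbers stand for higher lipophilicity and lower numbers for lower lipophilicity), compound 1 gives 2.24. Among the three measured compounds this is the lowest number: compound 2 `O=C(Nc1ccccc1)Nc1ccc(OC2=NS(=O)(=O)c3ccccc32)cc1`, which has an oxygen link and an unsubstituted phenyl on the urea, gives 2.89 in this assay, and the bromo analogue of compound 2, compound 3 `O=C(Nc1ccc(Br)cc1)Nc1ccc(OC2=NS(=O)(=O)c3ccccc32)cc1`, gives 3.64. Both gaps to compound 1 lie beyond the scatter.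

Compound 4 `O=C(Nc1ccccc1)Nc1ccc(NC2=NS(=O)(=O)c3ccccc32)cc1` is not yet measured. It differs from compound 1 by hydrogen in place of bromo on an aromatic carbon. For the measured compounds named here, the only measured step that bears on this change runs the other way and sits on the oxygen-linked pair rather than the amino-linked pair: a number 0.75 log units higher from compound 2 to compound 3 (beyond the scatter). Going by the values given here, no step on the amino-linked pair itself is available. Taking the oxygen-linked step as the best guide, removal of the bromo from compound 1 is expected to lower the number by a step of about the same size, a number 0.74 log units lower from compound 1 to compound 4 (beyond the scatter). Accordingly compound 4 is estimated at 1.5 in this assay, with a range from 1.05 to 1.95.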

Compound 4, partition coefficient: 2.23
Estimate against measurement, compound 4: 0.73 log units below; measured number above the stated range.
By their numbers in this assay, from the lowest: compounds 4 and 1 (each within the scatter of the next); then compound 2; then compound 3.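

In this assay the exchange of 3-bromophenyl for phenyl on the amino-linked urea gives a number 0.01 log units lower from compound 1 to compound 4 (within the scatter) and so leaves no readable difference on this pair. The earlier exchange, a number 0.75 log units higher from compound 2 to compound 3 (beyond the scatter) on the oxygen-linked pair, lies beyond the scatter, so the step between bromo and hydrogen does not carry over from that pair to this one, and the two pairs differ both in the link and in where the bromo sits on the terminal ring. Nothing measured here accounts for this contrast between the two pairs.

The compounds shown do not separate the link from the bromo's place, and an oxygen-linked analogue bearing 3-bromophenyl, together with an amino-linked analogue bearing the bromo as in compound 3, would be needed to tell which of the two goes with the contrast. As far as these compounds go, it also remains open whether this place on the ring stays as flat in this assay for other groups, such as a carboxylic acid, an amine or a longer alkyl chain, since bromo and hydrogen are the only two seen there.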